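A rearranged side chain on the shared core

A few compounds are considered here, and "the series" means these few. Any claim that something is new, unique, unknown or untested is made for them only; others in the source may bear on it.

In a functional assay on MCF7 cells (Homo sapiens) for inhibition, read by fluorescence, with a stated time of 72 h (on this read-out higher numbers stand for weaker inhibition and lower numbers for stronger inhibition), compound 3 (`CC(C)n1cnc2c(NC(=N)N)nc(N3CCC[C@H]3CO)nc21`) gives 6200 nM as the second highest of three numbers, with compound 1 (`CC[C@@H](CO)Nc1nc(NC(=N)N)c2ncn(C(C)C)c2n1`) at 1600 nM and compound 2 (`CC(C)[C@@H](N)COc1nc(NC(=N)N)c2ncn(C(C)C)c2n1`) at 79400 nM on either side. Compound 4 (`CC(C)n1cnc2c(NC(=N)N)nc(OC[C@H]3CCCN3)nc21`) carries (pyrrolidin-2-yl)methoxy in place of 2-(hydroxymethyl)pyrrolidin-1-yl on an aromatic carbon, which makes oxygen the link to the core. Only one oxygen-linked side chain has been measured, and both steps around it are large: a 50-fold higher number from compound 1 to compound 2 (1.70 log units; beyond the scatter) and a 13-fold lower number from compound 2 to compound 3 (1.11 log units; beyond the scatter) in the same assay. The step between the two nitrogen-linked side chains is modest: a 3.9-fold higher number from compound 1 to compound 3 (0.59 log units; beyond the scatter) only. A sizeable move to a higher number is therefore expected, namely a 5.6-fold higher number from compound 3 to compound 4 (0.75 log units; beyond the scatter) as the estimate. For compound 4 the estimate is 35000 nM with an expected range of 11000 nM to 100000 nM in this assay overall.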

Compound 4, half-maximal inhibitory concentration: > 100000 nM
Compound 4 gave a limit, no number; the forecaster's own chance of this, stated with the estimate: 15%; middle value at least 2.8-fold (0.45 log units) away from the limit.
By their numbers in this assay, from the lowest: compound 1; then compound 3; then compound 2. At a limit, above all of these: compound 4.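

Compound 4 gives no number, only a limit: the limit of > 100000 nM in this assay, at which 1 of the 4 values shown sits. With the same atoms joined differently, (pyrrolidin-2-yl)methoxy in place of 2-(hydroxymethyl)pyrrolidin-1-yl gives an at least 16-fold higher number from compound 3 to compound 4 (1.20 log units; beyond the scatter), and the listed step from the other nitrogen-linked side chain is an at least 62-fold higher number from compound 1 to compound 4 (1.79 log units; beyond the scatter). Both oxygen-linked side chains now stand at the high end of the series, and an at least 1.2-fold higher number from compound 2 to compound 4 (0.10 log units; that floor lies within the scatter) leaves the two unordered.

From the compounds shown here alone, whether the link atom or the rearranged ring carries the loss stays open. A (pyrrolidin-2-yl)methylamino side chain, with nitrogen as the link, would separate the two.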